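A few compounds are considered here, and "the series" means these few. Any claim that something is new, unique, unknown or untested is made for them only; others in the source may bear on it.

The measured compounds in a functional assay on the whole organism (aorta) with Rattus norvegicus as the target; on this read-out higher numbers stand for larger maximal responses and lower numbers for smaller maximal responses:

compound 1, `CCNS(=O)(=O)c1ccc2c(c1)C(n1ccccc1=O)=CC(C)(C)O2`, gives 72.4%
compound 2, `CC1(C)C=C(n2ccccc2=O)c2cc(S(=O)(=O)NCc3ccccc3)ccc2O1`, gives 71.1%
compound 3, `CC1(C)C=C(n2ccccc2=O)c2cc(S(=O)(=O)c3ccccc3)ccc2O1`, gives 79.3%

Compound 1 stands second highest of the three numbers in this assay, but neither neighbour is separated from it by more than the scatter: the step is a number 1.3 percentage points lower from compound 1 to compound 2 (within the scatter) and a number 6.9 percentage points higher from compound 1 to compound 3 (within the scatter). Likewise the step is a number 8.2 percentage points higher from compound 2 to compound 3 (within the scatter). Compound 4, `CC1(C)C=C(n2ccccc2=O)c2cc(S(=O)(=O)Oc3ccccc3)ccc2O1`, has not yet been measured. It differs from compound 1 in one place: phenoxy in place of ethylamino on a sulfonyl sulfur.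

The step that bears most closely on this change is the one where a phenyl enters on the same sulfonyl sulfur, a number 6.9 percentage points higher from compound 1 to compound 3 (within the scatter), supported by a number 8.2 percentage points higher from compound 2 to compound 3 (within the scatter); both replace an amino substituent on that sulfur with a carbon group and both stay within the scatter. Compound 4 is therefore expected to show no step beyond the scatter in this assay, with an estimated a number 3.6 percentage points higher from compound 1 to compound 4 (within the scatter). Compound 4 is estimated at 76%, within a range of 62% to 90%.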

Compound 4, largest response reached (Emax), in percent of the reference or control that the assay uses: 67.9%
Estimate against measurement, compound 4: 8.1 percentage points above; low and high end bracket the measured number.
By their numbers in this assay, from the lowest: compounds 4, 2, 1 and 3 (each within the scatter of the next, the first and the last beyond it).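

In this assay the sulfonyl sulfur shows its first step beyond the scatter, where phenoxy in place of phenyl gives a number 11.4 percentage points lower from compound 3 to compound 4 (beyond the scatter) and so separates two aromatic substituents that differ in how they are attached to the sulfur. Against the amino substituents the same phenoxy group stays within the scatter, with a number 4.5 percentage points lower from compound 1 to compound 4 (within the scatter) and a number 3.2 percentage points lower from compound 2 to compound 4 (within the scatter) as the two steps, so holding a six-membered aromatic ring does not alone set the number at this place. Nothing measured here accounts for the gap between phenyl and phenoxy.

As far as these compounds go, it remains open whether a benzyl or a phenylamino group on the sulfonyl sulfur would stand with compound 3 or with compound 4. From the compounds shown here alone, it is equally open where a methoxy group, which carries no ring, would fall.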